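Fluoro for methoxy on a shared core: expectation notes

This account rests on a few compounds, and the source may have more. Where it says the series, first, only, none or still open, it means among the compounds named here.

The series has three measured members on a shared core. Compound 1 `COc1ccccc1-c1n[nH]cc1N1CCNCC1` gives in an assay on isolated protein for binding affinity to 5-hydroxytryptamine receptor 4 (Homo sapiens) (a lower number here means a stronger inhibitor, a higher number a weaker inhibitor), a value of > 10000 nM, which is a limit of the assay and not a number. Compound 2 `COc1cccc(-c2n[nH]cc2N2CCNCC2)c1` likewise reaches only > 10000 nM in this assay, again a limit. Compound 3 `Clc1ccc(-c2n[nH]cc2N2CCNCC2)cc1` also stops at > 10000 nM in this assay, a limit as well. Compound 1 therefore stands at the limit, together with the other two measured compounds, as summarised by the limit of > 10000 nM in this assay, at which 3 of the 3 values shown sit. For the measured compounds named here, no single-point step between measured compounds is available, so no step size has been observed in this assay.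

Compound 4 `Fc1ccccc1-c1n[nH]cc1N1CCNCC1` differs from compound 1 by fluoro in place of methoxy on an aromatic carbon. With every measured value sitting at the limit, no direction or size of change beyond the scatter can be expected from the data. Compound 4 is therefore estimated at 20000 nM, within 5000 nM to 100000 nM, most likely again reported as a limit. The expected step from compound 1 to compound 4 is a step that the limit leaves unreadable from compound 1 to compound 4.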

Compound 4, inhibition constant: > 10000 nM
Compound 4: no number, only a limit (the forecaster's own chance of this, stated with the estimate: 80%); the middle value does not contradict the limit.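

The step from compound 1 to compound 4 cannot be read, since both values are limits and not numbers: the limit of > 10000 nM in this assay, at which 4 of the 4 values shown sit.

The compounds shown leave open whether any member of this series gives a real number in this assay, and how fluoro and methoxy compare there.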